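Replacing 4-chlorophenyl in compound 1 with 4-fluoro-3-nitrophenyl

A few compounds are considered here, and "the series" means these few. Any claim that something is new, unique, unknown or untested is made for them only; others in the source may bear on it.

Values measured in a functional assay on DU-145 cells (Homo sapiens) for inhibition, read by trypan blue exclusion, with a stated time of 96 h (a lower number here means a stronger inhibitor of growth, a higher number a weaker inhibitor of growth), follow
Compound 1 `O=C(/C(=C\c1ccc(Cl)cc1)S(=O)(=O)c1ccc(Br)cc1)c1ccc(Br)cc1` gives 50000 nM
Compound 2 `Cc1ccc(S(=O)(=O)/C(=C/c2ccc(O)c([N+](=O)[O-])c2)C(=O)c2ccc(Cl)cc2)cc1` gives 25000 nM
Compound 3 `COc1ccc(/C=C(/SCc2ccc(F)cc2)C(=O)c2ccc(Cl)cc2)c(OC)c1OC` gives 10000 nM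

Compound 1 stands at the weak end of this small set, though not alone. Compound 1 at 50000 nM and compound 2 at 25000 nM lie within the usual scatter of each other. Compound 3 gives 10000 nM and lies beyond the scatter on the stronger side of compound 1.

Compound 4 `O=C(/C(=C\c1ccc(F)c([N+](=O)[O-])c1)S(=O)(=O)c1ccc(Br)cc1)c1ccc(Br)cc1` has not yet been measured. It carries 4-fluoro-3-nitrophenyl in place of 4-chlorophenyl on a double-bonded chain carbon bound to a double-bonded chain carbon. Among the measured compounds shown here, no pair of measured compounds differs in one place only, so the data offer no direct guide to this change. Compound 2 also bears a nitro group, and at 25000 nM it offers no clear gain over compound 1. A modest step toward stronger inhibition in this assay is therefore expected, with little confidence in its size. The estimate means an expected 3.3-fold lower number from compound 1 to compound 4 (0.52 log units; beyond the scatter) in this direction. Compound 4 is estimated at 15000 nM (expected range 3000 nM to 50000 nM).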

Compound 4, concentration for 50% growth inhibition: 25000 nM
For compound 4 the middle estimate is 1.7-fold (0.22 log units) below the measured one; the measured number falls inside the stated range.
By their numbers in this assay, from the lowest: compound 3; then compounds 2, 4 and 1 (each within the scatter of the next).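

Among the compounds shown here, at this position, on a double-bonded chain carbon bound to a double-bonded chain carbon, the first comparison in one place in this assay reads a 2.0-fold lower number from compound 1 to compound 4 (0.30 log units; within the scatter) and so does not separate 4-fluoro-3-nitrophenyl from 4-chlorophenyl. The entering group has more heavy atoms than the group it replaces and brings hydrogen-bond acceptors that 4-chlorophenyl lacks, yet on the core of compound 1 these differences in structure leave the two compounds within the scatter of each other. Nothing measured here bears on why the two groups read alike.

As far as these compounds go, whether a fluorine or a nitro group alone at this position would read the same as the two together remains open, as does whether an amine or a carboxylic acid on the ring would give a number beyond the scatter of compound 1. The compounds shown also offer no comparison in one place anywhere else on the shared core, so it remains open whether other positions respond more sharply than this one.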